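This account rests on a few compounds, and the source may have more. Where it says the series, first, only, none or still open, it means among the compounds named here.

Of the compounds shown here, two have so far been measured in a functional assay on MGC-803 cells (Homo sapiens) for antiproliferative activity, read by CCK-8 assay, with a stated time of 72 h, tested at 8 uM; on this read-out lower numbers stand for a weaker effect and higher numbers for a stronger effect at the one concentration tested. Compound 1 `Nc1ccccc1NC(=O)c1ccc(CSC(=S)N2CCN(Cc3ccccn3)CC2)cc1` gives 65.2% in this assay, and compound 2 `CC1CCN(C(=S)SCc2ccc(C(=O)Nc3ccccc3N)cc2)CC1` gives 81.9%. Among these two numbers compound 1 stands lowest, and the only other value, that of compound 2, lies above it by more than the usual scatter.

Compound 3 `Nc1ccccc1NC(=O)c1ccc(CSC(=S)N2CCN(Cc3ccccc3)CC2)cc1` has not yet been tested. It differs from compound 1 in one place: phenyl in place of pyridin-2-yl on a saturated chain carbon bound to an amine nitrogen in a ring. Among the compounds with values here, no measured pair of compounds shows this particular change, so there is no measured step to lean on, and compound 2 alters a different part of the molecule, which says nothing about this one. One six-membered aromatic ring is replaced by another six-membered aromatic ring. The change is expected to make at most a small difference, within the scatter, with no clear direction. Compound 3 is therefore estimated to give 68% in this assay. Its likely range runs from 52% to 82%. That corresponds to an expected step of a number 2.8 percentage points higher from compound 1 to compound 3 (within the scatter).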

Compound 3, a percentage reported as inhibition, at one concentration (the size of the read-out at that concentration, not a potency): 19.7%
Estimate against measurement, compound 3: 48.3 percentage points above, outside the stated range (below it).
By their numbers in this assay, from the lowest: compound 3; then compound 1; then compound 2.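

In this assay, phenyl in place of pyridin-2-yl on a saturated chain carbon bound to an amine nitrogen in a ring gives a step of a number 45.5 percentage points lower from compound 1 to compound 3 (beyond the scatter), which is large and lies well beyond the usual scatter of repeated measurements. Within the data shown here, this place in the molecule is therefore sensitive to which six-membered aromatic ring it carries, even though both rings have the same count of heavy atoms and the exchange replaces only one ring nitrogen with carbon, taking away the one hydrogen-bond acceptor counted on that ring. No measurement at hand accounts for this drop, so its cause remains unknown.

A single pair on one core cannot show whether the ring nitrogen itself is what matters, or whether the same drop would appear with other parts of the molecule changed. A pyrimidine ring, with a second ring nitrogen, or a longer chain linking the ring to the amine nitrogen would test how far this sensitivity extends.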